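The compounds below may be only part of what the source reports. "The series", "measured", "known", "first", "only" and "open" are said of these compounds alone.

Series notes. The shared core carries a nitrile in compound 1, `COc1cc(N(C)CCN(C)C)c(NC(=O)/C=C\C(C)C)cc1Nc1ncc(C#N)c(-c2cn(C)c3ccccc23)n1`, and in compound 2, `CCC/C=C\C(=O)Nc1cc(Nc2ncc(C#N)c(-c3cn(C)c4ccccc34)n2)c(OC)cc1N(C)CCN(C)C`; it is replaced by a ring fluorine in compound 3, `COc1cc(N(C)CCN(C)C)c(NC(=O)/C=C\C(C)C)cc1Nc1nccc(-c2cn(C)c3ccc(F)cc23)n1`, and in the unmeasured compound 4, `CCC/C=C\C(=O)Nc1cc(Nc2nccc(-c3cn(C)c4ccc(F)cc34)n2)c(OC)cc1N(C)CCN(C)C`. How the core of compound 1 and the core of compound 3 differ is not broken down here. In a functional assay on A549 cells (Homo sapiens) for antiproliferative activity, read by MTT assay, with a stated time of 72 h (a higher number here means a weaker inhibitor, a lower number a stronger inhibitor), compound 1 gives 1100 nM, compound 2 gives 166 nM, and compound 3 gives 6140 nM, the highest of the three.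

The change from compound 1 to compound 2, (propyl in place of isopropyl on a double-bonded chain carbon bound to a double-bonded chain carbon), gave a 6.6-fold lower number from compound 1 to compound 2 (0.82 log units; beyond the scatter). The same change is made on the other core, from compound 3 to compound 4, (propyl in place of isopropyl on a double-bonded chain carbon bound to a double-bonded chain carbon), at the same place. Among the measured compounds shown here, this second instance is the only other occurrence of the change; whether the step transfers across the two cores is unknown, since no other pair tests it.

For compound 4 in this assay, a step of the same direction and broadly similar size is expected, resting on a 6.6-fold lower number from compound 1 to compound 2 (0.82 log units; beyond the scatter), so that the step amounts to a 5.6-fold lower number from compound 3 to compound 4 (0.75 log units; beyond the scatter). Compound 4 is thus estimated at 1100 nM, between 400 nM and 3500 nM.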

Compound 4, half-maximal inhibitory concentration: 1030 nM
For compound 4 the middle estimate is 1.1-fold (0.03 log units) above the measured one; the measured number falls inside the stated range.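

Replacing isopropyl with propyl on a double-bonded chain carbon bound to a double-bonded chain carbon gave, in this assay, a 6.0-fold lower number from compound 3 to compound 4 (0.78 log units; beyond the scatter), and this step matches the one on the other core: the same change on two cores in this assay, a 6.6-fold lower number (0.82 log units; beyond the scatter) from compound 1 to compound 2 and a 6.0-fold lower number (0.78 log units; beyond the scatter) from compound 3 to compound 4, 1.1-fold (0.05 log units) apart, within the scatter of two such steps. In this antiproliferative read-out, the change therefore carried from the core of compound 1 to the core of compound 3 in both direction and size, so for these two cores the step behaves as independent of the core. Two pairs do not show that it would hold on a further core or in another assay, and they give no explanation for why the propyl compounds have the lower numbers.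

On these data alone, it remains open whether a longer chain such as butyl, a cyclopropyl group or a chain ending in an amine at the same place would keep, extend or lose the step. Also open, as far as these compounds go, is how much the nitrile and the ring fluorine each contribute to the difference between the two cores, and whether the step survives on a core carrying both groups or neither.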